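Series notes: one stereocentre drawn without a configuration

A few compounds are considered here, and "the series" means these few. Any claim that something is new, unique, unknown or untested is made for them only; others in the source may bear on it.

In a physicochemical assay for lipophilicity, measured as chromatographic lipophilicity, at pH 7.4 (a lower number here means a more polar compound, a higher number a more lipophilic compound), compound 1 `COc1cc(-c2nnc3n2CCCC3(Cc2ccc(F)c(F)c2)C(C)(C)O)ccc1-c1cnc(C)o1` gives 3 and compound 2 `COc1cc(-c2nnc3n2CCC[C@@]3(Oc2cc(F)c(F)c(F)c2)C(C)(C)O)ccc1-c1cnc(C)o1` gives 3.2. These two values lie within the usual scatter of each other, and compound 2 stands level with compound 1 on the numbers available.

Compound 3 `COc1cc(-c2nnc3n2CCCC3(Oc2cc(F)c(F)c(F)c2)C(C)(C)O)ccc1-c1cnc(C)o1` has not yet been measured. Its relation to compound 2 is the two compounds have the same atoms and bonds; at least one stereo element is drawn with a configuration in one of them and without one in the other: 1 of 1 stereo elements differ; a stereocentre at a saturated ring carbon is drawn S in compound 2 and without a configuration in compound 3. The two compounds have the same atoms and bonds, and a stereocentre at a saturated ring carbon is drawn S in compound 2 and without a configuration in compound 3.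

For the measured compounds named here, no two measured compounds differ in one place only, and no measured step is available as a guide. The expectation rests on the structural comparison and on compound 2 at 3.2. The expected no change at the digits printed from compound 2 to compound 3 (within the scatter) in this assay stays within the scatter, with no direction favoured. Compound 3 is expected at 3.2, with an estimated range from 2.9 to 3.5.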

Compound 3, distribution coefficient: 3.2
For compound 3 middle estimate and measured number coincide at the digits printed; low and high end bracket the measured number.
By their numbers in this assay, from the lowest: compounds 1, 2 and 3 (each within the scatter of the next).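

Drawing the stereocentre at the saturated ring carbon as S or without a configuration goes with no change at the digits printed from compound 2 to compound 3 (within the scatter) in this assay, so the two drawings are not separated on this read-out. The earlier compounds shown here offered no comparison at a single place, and the exchange of 3,4-difluorobenzyl for 3,4,5-trifluorophenoxy on a saturated ring carbon now supplies one, with a number 0.20 log units higher from compound 1 to compound 3 (within the scatter). The first of these comparisons involves no change in atoms or bonds, and all that distinguishes the pair is this: the fact that one of compounds 2 and 3 is drawn with a defined configuration and the other without, at the place where they differ

As far as these compounds go, whether this assay stays within the scatter with a group of another kind on this carbon, such as an amine or a carboxylic acid in place of 3,4,5-trifluorophenoxy, remains open. The compounds shown also leave open how a form drawn with the opposite configuration would compare with compound 2.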